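Nitro in place of methyl on the benzyl ring

A few compounds are considered here, and "the series" means these few. Any claim that something is new, unique, unknown or untested is made for them only; others in the source may bear on it.

In a toxicity assay on NIH3T3 cells (Mus musculus) for cytotoxicity, read by resazurin assay (a lower number here means that less compound is needed, a higher number that more compound is needed for the effect), compound 3 `COC(=O)c1ccc(NCc2cncn2Cc2ccccc2C)cc1-c1ccccc1` gives 10000 nM. Compound 1 `COC(=O)c1ccc(NCc2cncn2Cc2ccccc2Cl)cc1-c1ccccc1` gives 10000 nM, and the step of no change at the digits printed from compound 1 to compound 3 (within the scatter) lies within the scatter, so compound 3 stands level with compound 1. Compound 2 `COC(=O)c1ccc(NCc2cncn2Cc2cccc([N+](=O)[O-])c2)cc1-c1ccccc1` gives > 10000 nM, which is a limit of the assay (the limit of > 10000 nM in this assay, at which 1 of the 3 values shown sits). Compound 4 `COC(=O)c1ccc(NCc2cncn2Cc2ccccc2[N+](=O)[O-])cc1-c1ccccc1` differs from compound 3 by nitro in place of methyl on an aromatic carbon. Among the measured compounds shown here, the steps that bear on this are a number no lower from compound 1 to compound 2 (the limit leaves the size open) and a number no higher from compound 2 to compound 3 (the limit leaves the size open), each bounded by the limit and of unreadable size, while the chloro-to-methyl exchange in no change at the digits printed from compound 1 to compound 3 (within the scatter) left the number unchanged. A nitro entering in place of methyl is thus expected to shift the number little, with any movement upward, and the step of no change at the digits printed from compound 3 to compound 4 (within the scatter) is the expected one. Compound 4 is estimated at 10000 nM, within 5000 nM to 20000 nM.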

Compound 4, half-maximal effective concentration: 10000 nM
Estimate against measurement, compound 4: no gap at the digits printed; the measured number falls inside the stated range.
By their numbers in this assay, from the lowest: compounds 1, 3 and 4 (each within the scatter of the next).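

In this assay the aromatic carbon ortho to a large group now carries nitro as well as chloro and methyl, and the exchanges read no change at the digits printed from compound 3 to compound 4 (within the scatter) and no change at the digits printed from compound 1 to compound 4 (within the scatter). The extra heavy atoms and the hydrogen-bond acceptors that enter with nitro leave the number in place on this carbon. Compound 2 stands at a limit of the assay: the limit of > 10000 nM in this assay, at which 1 of the 4 values shown sits. The remaining step reads a number no higher from compound 2 to compound 4 (the limit leaves the size open), and its size cannot be read.

Going by these compounds, whether an amine or a carboxylic acid on this same carbon would read level with these three compounds stays open.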